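Para-ethoxy anilino analogue of a weakly antiproliferative series

The source may hold more compounds than are shown below. What is called first, only, known or untested is meant among the compounds shown, and "the series" means these compounds.

Measured compounds:
- Compound 1, `CCCCOC1=C(C(=O)c2ccccc2)C(c2ccc(Br)cc2)N(CCCn2ccnc2)C1=O`: 32400 nM
- Compound 2, `Cc1ccc(NC2=C(C(=O)c3ccccc3)C(c3ccc(Br)cc3)N(CCCn3ccnc3)C2=O)cc1`: 24100 nM

In a functional assay on U2OS cells (Homo sapiens) for antiproliferative activity, read by MTT assay, with a stated time of 72 h (on this read-out lower numbers stand for stronger inhibition and higher numbers for weaker inhibition), compound 1 gives 32400 nM, and compound 2 gives 24100 nM. Going by the values given here, the only step among the measured compounds, a 1.3-fold lower number from compound 1 to compound 2 (0.13 log units; within the scatter), places compound 2 at the lower of the two numbers, yet the two values sit within the scatter of each other, so no order between compound 1 and compound 2 can be read from them.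

Compound 3, `CCOc1ccc(NC2=C(C(=O)c3ccccc3)C(c3ccc(Br)cc3)N(CCCn3ccnc3)C2=O)cc1`, keeps the core of compound 2 and differs from it by ethoxy in place of methyl on an aromatic carbon; seen one bond further out, this reads as (4-methylphenyl)amino to (4-ethoxyphenyl)amino. Among the compounds with values here, no measured step touches this part of the molecule: the step from compound 1 to compound 2 changed the group on the double-bonded ring carbon, not a substituent on the outer aromatic ring, and it stayed within the scatter. The data therefore give no basis for expecting a move beyond the scatter in this assay. Compound 3 is expected to give about 22000 nM, with a range from 8000 nM to 60000 nM, which amounts to an expected step of a 1.1-fold lower number from compound 2 to compound 3 (0.04 log units; within the scatter).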

Compound 3, half-maximal inhibitory concentration: 26200 nM
Beside the measured number, compound 3's estimate is 1.2-fold (0.08 log units) below it; low and high end bracket the measured number.
By their numbers in this assay, from the lowest: compounds 2, 3 and 1 (each within the scatter of the next).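

In this assay, going by these compounds alone, ethoxy in place of methyl on this aromatic carbon, para to a large group, gives a 1.1-fold higher number from compound 2 to compound 3 (0.04 log units; within the scatter), the first reading of a change at this position, and it stays within the scatter even though ethoxy carries a hydrogen-bond acceptor that methyl lacks. The (4-ethoxyphenyl)amino group also gives a 1.2-fold lower number from compound 1 to compound 3 (0.09 log units; within the scatter) when set in place of butoxy on the double-bonded ring carbon, so neither of the two anilino groups shown separates from butoxy, and the three compounds form one group with no order among them. No supporting data bear on this result.

The compounds shown leave open whether a different group on this aromatic carbon, such as a primary amine, a carboxylic acid or a longer chain like hexyloxy, would move the number beyond the scatter. They also leave open whether any change elsewhere on the shared core, for instance a chloro group in place of the bromo group, would do so.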